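The compounds below may be only part of what the source reports. "The series", "measured", "known", "first", "only" and "open" are said of these compounds alone.

compound 1 `O=C(CCCCC(S)CCS)NO` - "not determined" (no result reported)
compound 2 `O=C(CCCCC1CCSS1)Nc1cccc(C(F)(F)F)c1` - 88.7%

Among the measured compounds shown here, in a functional assay on PC-3 cells (Homo sapiens) for inhibition, read by MTT assay, with a stated time of 24 h, tested at 100 ug/mL (on this read-out higher numbers stand for more inhibition of growth at the one concentration tested and lower numbers for less inhibition of growth), compound 2 gives 88.7% as the only number so far, so it cannot yet be ranked against another compound. Compound 3 `O=C(CCCCC1CCSS1)Nc1ccc([N+](=O)[O-])c(C(F)(F)F)c1` differs from compound 2 by one change (nitro in place of hydrogen on an aromatic carbon): nitro in place of hydrogen on an aromatic carbon, ortho to a trifluoromethyl group and para to a large group. For the measured compounds named here, no measured step shows what such a change does, so the expectation rests on compound 2 alone. With compound 2 at 88.7% little room remains upward, so in this assay a flat result or a slight fall is expected, with no step beyond the usual scatter. The estimated step of a number 6.7 percentage points lower from compound 2 to compound 3 (within the scatter) stays within that scatter. For compound 3 the estimated value is 82% with an expected range from 60% to 98% on this read-out.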

Compound 3, percent growth inhibition at one concentration: 90.3%
For compound 3 the middle estimate is 8.3 percentage points below the measured one; low and high end bracket the measured number.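

In this assay, nitro in place of hydrogen on an aromatic carbon, ortho to a trifluoromethyl group and para to a large group, gives a number 1.6 percentage points higher from compound 2 to compound 3 (within the scatter). Among the compounds shown here, this is the first measured step, and it shows that this position accepts the nitro group with no readable change in growth inhibition at the one concentration tested. Nothing available explains this result.

On these data alone, whether an amine or a carboxylic acid at the same position would also leave the read-out unchanged remains open. Also open, as far as these compounds go, is whether compound 2 and compound 3 would separate at lower concentrations, since a single-concentration read-out gives no concentration-response information.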